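This account rests on a few compounds, and the source may have more. Where it says the series, first, only, none or still open, it means among the compounds named here.

In a functional assay on MOLT-4 cells (Homo sapiens) (on this read-out higher numbers stand for weaker inhibition and lower numbers for stronger inhibition), three compounds with a shared core have been measured. Compound 1 `Cc1ccc(-c2ncnc3c2ncn3C[C@@H]2C[C@H](CO)c3ccccc32)cc1`, carrying 4-methylphenyl, gives 1.4 ug/mL. Compound 2 `CCOc1ncnc2c1ncn2C[C@@H]1C[C@H](CO)c2ccccc21`, carrying ethoxy, gives 24 ug/mL, and compound 3 `CCCNc1ncnc2c1ncn2C[C@@H]1C[C@H](CO)c2ccccc21`, carrying propylamino, gives 24 ug/mL. Compound 3 therefore stands level with compound 2, and together they have the highest numbers of the three. Compound 4 `OC[C@H]1C[C@@H](Cn2cnc3c(NC4CC4)ncnc32)c2ccccc21` has cyclopropyl in place of propyl on a nitrogen on an aromatic ring. Removing 4-methylphenyl was a large step, a 17-fold higher number from compound 1 to compound 2 (1.23 log units; beyond the scatter) and a 17-fold higher number from compound 1 to compound 3 (1.23 log units; beyond the scatter). Exchanging ethoxy for propylamino was not, no change at the digits printed from compound 2 to compound 3 (within the scatter). Going by the values given here, no measured step changes the propyl alone, but this last step is the closest guide, so no step beyond the scatter is expected. The expected step is small, a 1.2-fold lower number from compound 3 to compound 4 (0.08 log units; within the scatter). Compound 4 is estimated at 20 ug/mL, within a range of 8 ug/mL to 50 ug/mL.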

Compound 4, half-maximal inhibitory concentration: 24 ug/mL
Compound 4: the middle estimate sits 1.2-fold (0.08 log units) below what was measured; measured number inside the range.
By their numbers in this assay, from the lowest: compound 1; then compounds 2, 3 and 4 (each within the scatter of the next).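

In this assay, closing the propyl into a cyclopropyl ring on the same nitrogen gives the same number (no change at the digits printed from compound 3 to compound 4 (within the scatter)), so on this nitrogen a small ring and an open chain read alike. Cyclopropylamino also reads the same as ethoxy (no change at the digits printed from compound 2 to compound 4 (within the scatter)), while the gap to the 4-methylphenyl of compound 1 stays large (a 17-fold higher number from compound 1 to compound 4 (1.23 log units; beyond the scatter)). Nothing measured here explains why these groups read alike.

Going by these compounds, whether a larger ring on the nitrogen, such as cyclohexyl, would still read the same stays open. So does whether plain phenyl would match 4-methylphenyl.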